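Swapping a branched alkyl for a difluorophenyl at the imidazole

The source may hold more compounds than are shown below. What is called first, only, known or untested is meant among the compounds shown, and "the series" means these compounds.

Measured compounds:
- compound 1, `O=C(O)c1ccccc1-c1ccc(CCc2ncc(Cc3cccc(F)c3)[nH]2)cc1`: 159 nM
- compound 2, `N#Cc1cccc(Cc2cnc(CCc3ccc(-c4ccccc4C(=O)O)cc3)[nH]2)c1`: 812 nM
- compound 3, `CCC(C)(CC)Cc1cnc(CCc2ccc(-c3ccccc3C(=O)O)cc2)[nH]1`: 76 nM

All three share one core and differ only in the group hanging from the saturated chain carbon bound to an aromatic carbon. In an in vitro functional assay on cells for agonist activity at Bombesin receptor subtype-3 (Homo sapiens), read by luminescence and calcium flux (on this read-out higher numbers stand for an effect only at larger amounts of compound and lower numbers for an effect already at smaller amounts), compound 3 gives the lowest number of the three, with compound 1 nearest and compound 2 furthest. Compound 4, `O=C(O)c1ccccc1-c1ccc(CCc2ncc(Cc3cccc(F)c3F)[nH]2)cc1`, carries the change (2,3-difluorophenyl in place of 1-ethyl-1-methylpropyl on a saturated chain carbon bound to an aromatic carbon). Going by the values given here, two measured steps bear on this: the aryl-to-alkyl step a 2.1-fold lower number from compound 1 to compound 3 (0.32 log units; beyond the scatter) and the larger step of an 11-fold lower number from compound 2 to compound 3 (1.03 log units; beyond the scatter). Among the compounds with values here, compound 4 returns to an aryl group that resembles the one in compound 1 but with a second fluorine, so the step is expected to run back in the direction of compound 1, roughly undoing a 2.1-fold lower number from compound 1 to compound 3 (0.32 log units; beyond the scatter). For compound 4 a modest rise is therefore expected, a 2.4-fold higher number from compound 3 to compound 4 (0.37 log units; beyond the scatter). The estimate for compound 4 is 180 nM, with a range from 80 nM to 450 nM.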

Compound 4, half-maximal effective concentration: 87 nM
Compound 4: the middle estimate sits 2.1-fold (0.32 log units) above what was measured, and the stated range covers the measured number.
By their numbers in this assay, from the lowest: compounds 3, 4 and 1 (each within the scatter of the next, the first and the last beyond it); then compound 2.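

In this assay the step of a 1.1-fold higher number from compound 3 to compound 4 (0.06 log units; within the scatter) stays within the scatter, so the 2,3-difluorophenyl and 1-ethyl-1-methylpropyl groups cannot be told apart at this position. The added fluorine gives a 1.8-fold lower number from compound 1 to compound 4 (0.26 log units; within the scatter) and that too lies within the scatter, so no effect of it can be claimed. The 3-cyanophenyl group of compound 2 behaves differently: a 9.3-fold lower number from compound 2 to compound 4 (0.97 log units; beyond the scatter) lies beyond the scatter, so carrying an aromatic ring at this position does not by itself settle the number.

Going by these compounds, whether a methoxy group or an amine on the ring, or a longer chain in place of the branched alkyl group, would give a similar number remains open. Nothing shown accounts for the different behaviour of the nitrile-bearing ring.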